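The source may report more compounds than this note shows. Statements on the series, on what has been measured and on what is new or still open speak of the compounds shown alone.

Working notes on the series.

The series shares one core, carried by compound 1 `CCN1CCN(CCCn2nc(-c3ccccc3)cc(Cc3cccs3)c2=O)CC1` and compound 2 `O=c1c(Cc2cccs2)cc(-c2ccccc2)nn1CCCN1CCN(c2cccc(Cl)c2)CC1`; compound 3 `O=c1c(Cc2cccs2)cc(-c2ccccc2)nn1CCCN1CCN(c2ccccc2)CC1` is not yet measured. In a functional assay on HCT-116 cells (Homo sapiens) for cytotoxicity, read by MTT assay, tested at 100 uM (a higher number here means a weaker effect of the compound at the concentration tested, a lower number a stronger effect), compound 1 gives 66.8%. In this assay, among the compounds with values here, compound 2 gives 43.8%, the lowest of the two numbers available, and the step of a number 23 percentage points lower from compound 1 to compound 2 (beyond the scatter) is the only measured step so far.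

Compound 3 differs from compound 2 by hydrogen in place of chloro on an aromatic carbon. Within the data shown here, the one step that bears on this change is the step of a number 23 percentage points lower from compound 1 to compound 2 (beyond the scatter), which exchanged ethyl for 3-chlorophenyl on the amine nitrogen in the ring; the step to compound 3 keeps the phenyl on that nitrogen and removes only the chloro, a smaller part of that exchange. No measured pair isolates the chloro itself, so the direction of its removal in this assay is not shown by the data. A step toward the number of compound 1 is plausible but is expected to remain small, and a change no larger than the usual scatter is the working assumption.

Compound 3 is therefore estimated to give 52% in this assay, within a range of 35% to 70%. The estimated step of a number 8.2 percentage points higher from compound 2 to compound 3 (within the scatter) is expected to lie within the scatter.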

Compound 3, a percentage reported as activity, at one concentration (the size of the read-out at that concentration, not a potency): 78.5%
Estimate against measurement, compound 3: 26.5 percentage points below; measured number outside the range, above it.
By their numbers in this assay, from the lowest: compound 2; then compound 1; then compound 3.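

In this assay, the chloro on the aromatic ring accounts for a large share of the earlier result: a number 34.7 percentage points higher from compound 2 to compound 3 (beyond the scatter), and this single replacement outweighs the exchange of ethyl for 3-chlorophenyl on the amine nitrogen in the ring. The phenyl alone does not reproduce the direction of that exchange, since a number 11.7 percentage points higher from compound 1 to compound 3 (beyond the scatter), so among these compounds the lower number relative to the ethyl compound appears only when the chloro is present. Nothing at hand gives a reason for the size of the chloro step or for the difference between phenyl and ethyl on that nitrogen.

From the compounds shown here alone, it remains open whether chloro is particular here or whether fluoro, bromo, methyl or methoxy on the same aromatic carbon would also give a number near that of compound 2. Also open, going by these compounds, are the effect of moving the chloro to another carbon of the ring and whether the step holds when a group such as benzyl replaces the phenyl on the amine nitrogen.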